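Moving the Trifluoromethyl Group on Compound 1

This account rests on a few compounds, and the source may have more. Where it says the series, first, only, none or still open, it means among the compounds named here.

Among the measured compounds shown here, compound 1 `CN(C(=O)NC(=O)c1cccc(C(F)(F)F)c1)c1nc(C(F)(F)F)c(C(=O)N/N=C/c2cccc(C(F)(F)F)c2)s1` gives in a functional assay on MCF7 cells (Homo sapiens) for inhibition, read by MTT assay, with a stated time of 72 h (a lower number here means a stronger inhibitor, a higher number a weaker inhibitor), a value of 3.7 ug/mL, the lowest of the three numbers measured so far. Compound 2 `CN(C(=O)NC(=O)c1ccc([N+](=O)[O-])cc1)c1nc(C(F)(F)F)c(C(=O)N/N=C/c2cccc(C(F)(F)F)c2)s1` gives 4.39 ug/mL in this assay, and compound 3 `CN(C(=O)NC(=O)c1ccc(F)c(F)c1)c1nc(C(F)(F)F)c(C(=O)N/N=C/c2cccc(C(F)(F)F)c2)s1` gives 4.15 ug/mL. The steps of a 1.2-fold higher number from compound 1 to compound 2 (0.07 log units; within the scatter) and a 1.1-fold higher number from compound 1 to compound 3 (0.05 log units; within the scatter) both fall within the scatter, and both replace a group on a carbonyl carbon. Compound 4 `CN(C(=O)NC(=O)c1cccc(C(F)(F)F)c1)c1nc(C(F)(F)F)c(C(=O)N/N=C/c2ccc(C(F)(F)F)cc2)s1` differs from compound 1 elsewhere: 4-(trifluoromethyl)phenyl in place of 3-(trifluoromethyl)phenyl on a carbon with a double bond to nitrogen. For the measured compounds named here, no measured step touches that position, so the earlier steps give only indirect guidance, and they show little response to changing an aryl group at all. Compound 4 is therefore expected to show a 1.1-fold higher number from compound 1 to compound 4 (0.03 log units; within the scatter), nothing beyond the scatter. The estimate for compound 4 is 4 ug/mL, within a range of 2 ug/mL to 8 ug/mL.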

Compound 4, half-maximal inhibitory concentration: 6.5 ug/mL
The estimate for compound 4 lay 1.6-fold (0.21 log units) below the measured number; the range from low to high includes it.
By their numbers in this assay, from the lowest: compounds 1, 3, 2 and 4 (each within the scatter of the next).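

Among the compounds shown here, compound 4 gives the first reading at the aryl group on the carbon with a double bond to nitrogen. In this assay, 4-(trifluoromethyl)phenyl in place of 3-(trifluoromethyl)phenyl gives a 1.8-fold higher number from compound 1 to compound 4 (0.24 log units; within the scatter) and so stays within the scatter, which means this position shows no clear response to relocating the trifluoromethyl group. No available evidence bears on this result.

On these data alone, all the aryl groups at this position still carry trifluoromethyl, so the effect of replacing it with an amine or a carboxylic acid remains open.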